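Swapping a halogen on the aryl group of compound 1

The compounds below may be only part of what the source reports. "The series", "measured", "known", "first", "only" and "open" are said of these compounds alone.

This study concerns a small set of compounds sharing one core, tested in a functional assay on FOCUS cells (Homo sapiens) for inhibition, read by sulforhodamine B assay, with a stated time of 72 h; on this read-out higher numbers stand for weaker inhibition and lower numbers for stronger inhibition. Compound 1, with the structure `CC(c1ccc(-c2ccccc2)c(F)c1)c1nnc2n1N=C(c1ccc(Cl)cc1)CS2`, gives 5000 nM. Compound 2, `CC(C)Cc1ccc(C(C)c2nnc3n2N=C(c2ccc(Br)cc2)CS3)cc1`, gives 5900 nM. Of the two numbers reported, compound 1 has the lower one, but the two values lie within the usual scatter of such measurements, so no order between compound 1 and compound 2 can be read from them. A third compound, compound 3, `CC(c1ccc(-c2ccccc2)c(F)c1)c1n[nH]c(=S)n1N`, lacks the closed ring system of the other two and was reported as "not active" (no number reported), without a number.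

The unmeasured compound 4, `CC(c1ccc(-c2ccccc2)c(F)c1)c1nnc2n1N=C(c1ccc(F)cc1)CS2`, differs from compound 1 in one place: fluoro in place of chloro on an aromatic carbon. Compound 2 carries bromo at the matching spot, and its value sits close to that of compound 1, which suggests the identity of the halogen at this position has left little mark so far.

Compound 4 is therefore expected to stay near compound 1 in this assay, with a step of a 1.4-fold higher number from compound 1 to compound 4 (0.15 log units; within the scatter) that remains within the scatter. The estimate for compound 4 is 7000 nM, within a range from 3000 nM to 18000 nM.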

Compound 4, half-maximal inhibitory concentration: 3500 nM
Beside the measured number, compound 4's estimate is 2.0-fold (0.30 log units) above it; the range from low to high includes it.
By their numbers in this assay, from the lowest: compounds 4, 1 and 2 (each within the scatter of the next).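

For the compounds shown here, until now, no two measured compounds differed in one place only, so the halogen on this aryl group could not be judged on its own; compound 1 and compound 4 supply that clean comparison. In this assay, the swap from 4-chlorophenyl to 4-fluorophenyl gives a 1.4-fold lower number from compound 1 to compound 4 (0.15 log units; within the scatter) and so separates the two compounds by no more than repeat measurements would, which means that neither can be ranked above the other and that this position accepts either halogen with the activity left in the same range. No measurement is available that could explain this result.

The compounds shown leave open whether this position would respond differently to a group that is not a halogen, such as an amine, a methoxy group or a carboxylic acid, placed on the same aromatic carbon. They also leave open whether the swap from chloro to fluoro would read the same way if the aryl group at the other end of the shared core were changed, as it is in compound 2.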